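Changing the chain end of compound 2

A few compounds are considered here, and "the series" means these few. Any claim that something is new, unique, unknown or untested is made for them only; others in the source may bear on it.

In a functional assay for inhibition, with Homo sapiens as the target (on this read-out lower numbers stand for stronger inhibition and higher numbers for weaker inhibition), compound 1 `COC(=O)CCCCCCCCn1nc(-c2ccccc2)c(-c2ccccc2)c1-c1ccccc1` gives 4300 nM. Compound 2 `CC(C)(C)OC(=O)COCCCCCCn1nc(-c2ccccc2)c(-c2ccccc2)c1-c1ccccc1` is reported only as a limit, > 62000 nM, and not as a number. Compound 2 therefore sits at the limit of > 62000 nM in this assay, at which 1 of the 2 values shown sits.

Compound 3 `O=C(O)CSCCCCCCn1nc(-c2ccccc2)c(-c2ccccc2)c1-c1ccccc1` has (carboxymethyl)sulfanyl in place of (tert-butoxycarbonyl)methoxy on a saturated chain carbon, six bonds along the chain from an aromatic nitrogen.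

For the measured compounds named here, only one measured step bears on this change: an at least 14-fold higher number from compound 1 to compound 2 (1.15 log units; beyond the scatter). Going by the values given here, that large step brought in the same (tert-butoxycarbonyl)methoxy group that leaves here, so a large step towards stronger inhibition is expected in this assay, although the incoming group is not the one compound 1 carries. The expected step is an at least 17-fold lower number from compound 2 to compound 3 (1.24 log units; beyond the scatter). Compound 3 is estimated at 3500 nM, with an expected range of 400 nM to 30000 nM.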

Compound 3, half-maximal inhibitory concentration: 870 nM
For compound 3 the middle estimate is 4.0-fold (0.60 log units) above the measured one; measured number inside the range.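

Compound 2 is reported only as a limit, not as a number: the limit of > 62000 nM in this assay, at which 1 of the 3 values shown sits. In this assay, replacing (tert-butoxycarbonyl)methoxy with (carboxymethyl)sulfanyl gives an at least 71-fold lower number from compound 2 to compound 3 (1.85 log units; beyond the scatter), so the end of this chain can separate a compound with a measurable value from one reported only as a limit. The same end also improves on the 2-(methoxycarbonyl)ethyl end, with a 4.9-fold lower number from compound 1 to compound 3 (0.69 log units; beyond the scatter), so inhibition at this place is not limited to what compound 1 reached.

This change swaps the chain's oxygen for sulfur and the tert-butyl ester for a carboxylic acid at once, so the compounds shown cannot say which of the two carries the step. As far as these compounds go, a (carboxymethyl)oxy end would separate them, while an amide at the chain end or a longer chain remains open.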